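Amino in Place of 4-Methylpiperazin-1-yl on the Carbonyl

The source may hold more compounds than are shown below. What is called first, only, known or untested is meant among the compounds shown, and "the series" means these compounds.

Compound 1 `CN1CCN(C(=O)/C=C/c2ccncc2-c2ccc3ccccc3c2)CC1` was tested in a functional assay on MCF7 cells (Homo sapiens) for inhibition, read by sulforhodamine B assay, with a stated time of 72 h; a lower number here means a stronger inhibitor of growth, a higher number a weaker inhibitor of growth. In this assay compound 1 gives only a limit, > 10000 nM. Two further compounds carry the same chain ending in a carbonyl, on another core. Compound 2 `CNC(=O)/C=C/c1ccncc1-c1ccc2cc[nH]c2c1` gives 9230 nM in this assay. Compound 3 `O=C(/C=C/c1ccncc1-c1ccc2cc[nH]c2c1)N1CCOCC1` reaches only the limit of this assay, > 10000 nM. Within the data shown here, the single step measured between neighbours, an at least 1.0-fold higher number from compound 2 to compound 3 (0.03 log units; that floor lies within the scatter), puts morpholin-4-yl in place of methylamino on a carbonyl carbon and shows nothing beyond the scatter; that compound 1 and compound 3 both sit at the limit of > 10000 nM in this assay, at which 2 of the 3 values shown sit, leaves the true size of any difference unknown.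

Compound 4 `NC(=O)/C=C/c1ccncc1-c1ccc2ccccc2c1` has not yet been measured. It differs from compound 1 by amino in place of 4-methylpiperazin-1-yl on a carbonyl carbon. The measured step runs the opposite way, from methylamino to morpholin-4-yl, and moved nothing visibly, so the reverse kind of change is expected to move little as well. Compound 4 is therefore expected to show an at least 1.1-fold lower number from compound 1 to compound 4 (0.04 log units; that floor lies within the scatter), that is an estimated 9000 nM, within 3000 nM to 25000 nM, with a fair chance that only a limit is reported.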

Compound 4, concentration for 50% growth inhibition: > 10000 nM
Compound 4: only a limit was reported (the forecaster's own chance of this, stated with the estimate: 50%); middle value at least 1.1-fold (0.04 log units) from the limit.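

Compound 1 and compound 4 each give only a limit in this assay, so the step between them cannot be read: the limit of > 10000 nM in this assay, at which 3 of the 4 values shown sit.

The compounds shown leave open how far amino and 4-methylpiperazin-1-yl on the carbonyl carbon truly differ, and whether any group there gives a readable number on the core of compound 1.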